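The source may hold more compounds than are shown below. What is called first, only, known or untested is meant among the compounds shown, and "the series" means these compounds.

Compound 1, `Oc1ccc(-c2cc(-c3cccs3)cc(-c3ccccc3O)n2)cc1`: 2%
Compound 2, `Oc1ccccc1-c1cc(-c2cccnc2)cc(-c2ccccc2O)n1`: 0%

In an assay on isolated protein for inhibition of DNA topoisomerase 1 (Homo sapiens), with a stated time of 30 min, tested at 20 uM (a higher number here means a stronger effect of the compound at the concentration tested, a lower number a weaker effect), compound 1 gives 2%. Compound 2 gives 0%, the lowest of the two numbers, though its gap to compound 1 lies within the usual scatter, so the two results cannot be told apart and both sit close to no effect at the tested concentration.

Compound 3, `Oc1ccc(-c2cc(-c3cccnc3)cc(-c3ccccc3O)n2)cc1`, has not yet been measured. It carries the same atoms as compound 2, joined differently: 4-hydroxyphenyl in place of 2-hydroxyphenyl on an aromatic carbon. Among the measured compounds shown here, no measured pair shows what this change alone does. Since compound 1, which already carries a 4-hydroxyphenyl group, gives 2% in this assay, there is no sign that this group raises the read-out, and the step is expected to stay within the scatter, a number 2 percentage points higher from compound 2 to compound 3 (within the scatter). Compound 3 is therefore estimated to give about 2%, with a range from -5% to 12%.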

Compound 3, a percentage reported as inhibition, at one concentration (the size of the read-out at that concentration, not a potency): 0%
Compound 3: middle estimate off by 2 percentage points, on the high side; the range from low to high includes it.
By their numbers in this assay, from the lowest: compounds 2, 3 and 1 (each within the scatter of the next).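

In this assay, 4-hydroxyphenyl in place of 2-hydroxyphenyl on the aromatic carbon next to the ring nitrogen gives no change at the digits printed from compound 2 to compound 3 (within the scatter), so this change now has a direct reading, and it does not lift the result clear of the scatter. Compound 3 also forms a pair with compound 1, which shows pyridin-3-yl in place of thiophen-2-yl giving a number 2 percentage points lower from compound 1 to compound 3 (within the scatter), again with no step beyond the scatter. There is no independent information that would explain either reading.

All three compounds sit close to no effect, so any change that would weaken the effect further could hardly show up here. On these data alone, whether another group at this position, such as an amine or a carboxylic acid, would give a clear effect remains open.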